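The source may hold more compounds than are shown below. What is called first, only, known or untested is meant among the compounds shown, and "the series" means these compounds.

Measured compounds:
compound 1 `COc1cc(-c2cc(C(=O)O)c3ccccc3n2)ccc1OCC(=O)Nc1ccccc1C` — 0.8
compound 2 `COc1cc(-c2cc(C(=O)O)c3ccccc3n2)ccc1OCC(=O)Nc1ccccc1Cl` — 1.6
compound 3 `COc1cc(-c2cc(C(=O)O)c3ccccc3n2)ccc1OCC(=O)Nc1cccc(Cl)c1` — 2.3

In a physicochemical assay for lipophilicity, using the shake flask method, in phosphate buffer, measured as octanol-water partition, at pH 7.4 (a higher number here means a more lipophilic compound, a lower number a more polar compound), compound 3 stands highest of the three, with compound 2 nearest and compound 1 furthest. Both measured steps leading there are beyond the scatter: a number 0.80 log units higher from compound 1 to compound 2 (beyond the scatter) and a number 0.70 log units higher from compound 2 to compound 3 (beyond the scatter); taken together they give a number 1.50 log units higher from compound 1 to compound 3 (beyond the scatter).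

Compound 4 `COc1cc(-c2cc(C(=O)O)c3ccccc3n2)ccc1OCC(=O)Nc1ccc(C(F)(F)F)cc1` differs from compound 3 by 4-(trifluoromethyl)phenyl in place of 3-chlorophenyl on an amide-type nitrogen. Among the compounds with values here, no measured pair covers this exact change. The step from compound 1 to compound 2 shows that exchanging one substituent for another on the aryl amide moves this assay by a modest amount, and the step from compound 2 to compound 3 shows that moving a substituent around that ring does as well. Compound 4 combines a new substituent with a new position, so a modest upward step is expected rather than none, with wide uncertainty: the expected step is a number 0.30 log units higher from compound 3 to compound 4 (within the scatter). For compound 4 the estimate in this assay is 2.6, with a range from 2.1 to 3.1.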

Compound 4, distribution coefficient: 1.6
For compound 4 the middle estimate is 1.00 log units above the measured one, outside the stated range (below it).
By their numbers in this assay, from the lowest: compound 1; then compounds 2 and 4 (each within the scatter of the next); then compound 3.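

In this assay the exchange of 3-chlorophenyl for 4-(trifluoromethyl)phenyl on the amide-type nitrogen gives a number 0.70 log units lower from compound 3 to compound 4 (beyond the scatter) and so lowers the number, although the entering group counts 10 heavy atoms against 7. The same group in place of 2-chlorophenyl gives no change at the digits printed from compound 2 to compound 4 (within the scatter) and so puts two different aryl amides level, while in place of 2-methylphenyl it gives a number 0.80 log units higher from compound 1 to compound 4 (beyond the scatter) and keeps compound 1 lowest. Compound 3 therefore remains highest of the four, its steps to all others beyond the scatter, and neither heavy atom count nor the mere presence of a halogen orders these compounds.

On these data alone, compound 4 changes substituent and place together, so their separate shares stay open, as does the outcome for a nitrile or an amine on that ring. No measurement shown gives a reason for these steps.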